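Trading Dimethylamino for Bromo on the Shared Core

The compounds below may be only part of what the source reports. "The series", "measured", "known", "first", "only" and "open" are said of these compounds alone.

Measured so far in a functional assay on KB cells (Homo sapiens) for inhibition; on this read-out lower numbers stand for stronger inhibition and higher numbers for weaker inhibition:
- compound 1 `OCC(CO)OCn1c(SCc2ccccc2)nc2cc(Cl)c(Cl)cc21`: compound 1 gives > 100000 nM, which is a limit of the assay and not a number.
- compound 2 `CN(C)c1nc2c(Cl)cc(Cl)cc2n1COC(CO)CO`: compound 2 gives > 100000 nM, again a limit of the assay and not a number.

Among the compounds with values here, compound 2 therefore stands at the edge of what this assay can report, and the only other value, that of compound 1, sits at the same edge, as the limit of > 100000 nM in this assay, at which 2 of the 2 values shown sit, states. Within the data shown here, no step between two measured compounds is available to calibrate what a change on the shared core does here.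

Compound 3 `OCC(CO)OCn1c(Br)nc2c(Cl)cc(Cl)cc21` differs from compound 2 in one place: bromo in place of dimethylamino on an aromatic carbon. With both measured compounds at the limit, there is no basis for expecting a step of any particular size or direction in this assay; the expectation is none beyond the scatter, and most likely another limit. Compound 3 is thus estimated at 150000 nM, within a range of 30000 nM to 1000000 nM, which corresponds to an expected step that the limit leaves unreadable from compound 2 to compound 3.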

Compound 3, half-maximal inhibitory concentration: > 100000 nM
Compound 3: a limit, no number; the forecaster's own chance of this, stated with the estimate: 85%; the middle value does not contradict the limit.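

Compound 3 gives > 100000 nM in this assay, which is a limit of the assay and not a number. Compound 2 also stands at a limit, and no step can be read between compound 2 and compound 3. The compounds shown leave open whether any change on the shared core would give a readable value in this assay.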